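The source may hold more compounds than are shown below. What is called first, only, known or untested is meant among the compounds shown, and "the series" means these compounds.

Compound 1 `COc1ccc(-c2nc3cnccn3c2Nc2cc(OC)c(OC)c(OC)c2)cc1`: 75000 nM
Compound 2 `COc1ccc(Nc2c(-c3ccc(OC)c(O)c3)nc3cnccn23)cc1`: 62000 nM

In an ADME assay on Vero cells (Chlorocebus sabaeus) for cytotoxicity, read by MTT assay (on this read-out higher numbers stand for lower toxicity in this test and lower numbers for higher toxicity in this test), compound 1 gives 75000 nM and compound 2 gives 62000 nM, so the two stand within the scatter of each other. Compound 3 `COc1cc(Nc2c(C3C=Nc4ccccc43)nc3cnccn23)cc(OC)c1OC` differs from compound 1 at one place: a group of 9 heavy atoms (8 carbon, 1 nitrogen; one five-membered non-aromatic ring with 1 hetero atom, one six-membered aromatic ring of carbon only) in place of a group of 8 heavy atoms (7 carbon, 1 oxygen; one six-membered aromatic ring of carbon only), on an aromatic carbon. Going by the values given here, no measured step covers this change, and the only guide is the closeness of these two values. The expected change is a 1.4-fold lower number from compound 1 to compound 3 (0.13 log units; within the scatter), with no step beyond the scatter expected. For compound 3 the estimated value is 55000 nM, within an expected range of 22000 nM to 110000 nM.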

Compound 3, concentration lethal to 50% of the cells: 70000 nM
Estimate against measurement, compound 3: 1.3-fold (0.10 log units) below; low and high end bracket the measured number.
By their numbers in this assay, from the lowest: compounds 2, 3 and 1 (each within the scatter of the next).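

Working from the 4-methoxyphenyl of compound 1, the group with a five-membered non-aromatic ring with 1 hetero atom on this aromatic carbon gives, in this assay, a 1.1-fold lower number from compound 1 to compound 3 (0.03 log units; within the scatter). The position therefore takes a group without an aryl ring attached directly, with no step beyond the scatter on this read-out. Nothing at hand bears on the reason for this result.

Going by these compounds, whether a charged group such as a carboxylic acid or an amine on this carbon stays within the scatter remains open. On these data alone, a small group such as methyl is equally open.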